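Flipping a Ring Stereocentre: What to Expect for Compound 4

A few compounds are considered here, and "the series" means these few. Any claim that something is new, unique, unknown or untested is made for them only; others in the source may bear on it.

The three compounds measured so far in a physicochemical assay for lipophilicity, read by HPLC, measured as octanol-water partition, at pH 7.4 (a higher number here means a more lipophilic compound, a lower number a more polar compound), are:

Compound 1 `CC1(C)C[C@@H](CN([C@H](CCC(F)(F)F)C(N)=O)S(=O)(=O)c2ccc(Cl)cc2)O1` gives 3.8.
Compound 2 `CC1(C)C[C@H](CN([C@H](CCC(F)(F)F)C(N)=O)S(=O)(=O)c2ccc(Cl)cc2)O1` gives 3.8.
Compound 3 `CC1(C)CO[C@@H]1CN([C@H](CCC(F)(F)F)C(N)=O)S(=O)(=O)c1ccc(Cl)cc1` gives 3.9.

Compound 3 carries the highest of the three numbers, but only barely: the step of a number 0.10 log units higher from compound 1 to compound 3 (within the scatter) and the step of a number 0.10 log units higher from compound 2 to compound 3 (within the scatter) both sit within the scatter, so the three compounds cannot be told apart on this measure.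

Compound 4 `CC1(C)CO[C@H]1CN([C@H](CCC(F)(F)F)C(N)=O)S(=O)(=O)c1ccc(Cl)cc1` is the next compound. Its difference from compound 3 is this: the two compounds have the same atoms and bonds and differ only in configuration as drawn: 1 of 2 stereo elements differ; a stereocentre at a saturated ring carbon is drawn S in compound 3 and R in compound 4.

Going by the values given here, one measured step bears directly on this change, due to the fact that compounds 1 and 2 differ only in the configuration as drawn. That step, no change at the digits printed from compound 1 to compound 2 (within the scatter), shows that drawing the ring stereocentre the other way left the number where it was. The same kind of change now separates compound 3 from compound 4, so the expected step of no change at the digits printed from compound 3 to compound 4 (within the scatter) is none beyond the scatter. Compound 4 is therefore estimated at 3.9, with a range from 3.6 to 4.2.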

Compound 4, distribution coefficient: 3.8
Beside the measured number, compound 4's estimate is 0.10 log units above it, and the stated range covers the measured number.
By their numbers in this assay, from the lowest: compounds 1, 2, 4 and 3 (each within the scatter of the next).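

Flipping the ring stereocentre on the 3,3-dimethyloxetan-2-yl group gives a number 0.10 log units lower from compound 3 to compound 4 (within the scatter), so the flip first seen with the 4,4-dimethyloxetan-2-yl group now has a second reading in this assay. Moving to the 3,3-dimethyloxetan-2-yl group with the stereocentre drawn this new way gives no change at the digits printed from compound 2 to compound 4 (within the scatter) and no change at the digits printed from compound 1 to compound 4 (within the scatter). Across these four compounds, neither change carries the number beyond the scatter, and the flip can be read on its own here: the fact that compounds 3 and 4 differ only in the configuration as drawn

As far as these compounds go, it remains open whether configuration at this position stays as unimportant when a group such as an amine or a carboxylic acid is attached to the ring in place of the two methyl groups. From the compounds shown here alone, whether it matters in any other kind of test is also open, with only this assay in hand.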